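This account rests on a few compounds, and the source may have more. Where it says the series, first, only, none or still open, it means among the compounds named here.

Working notes on the series.

Compound 1 `O=C(O)c1ccc(COc2ccc(CNC(=O)[C@@H]3CCC(=O)N3Cc3ccccc3)cc2)cc1` is the reference point. In an assay on HEK293 cells for inhibition of Ataxin-2 (Mus musculus), read by fluorescence and Amplex Red (a higher number here means a weaker inhibitor, a lower number a stronger inhibitor), compound 1 gives 4500 nM. Compound 2 `O=C(O)c1ccc(COc2ccc(CNC(=O)[C@H]3CCC(=O)N3Cc3ccccc3)cc2)cc1` gives in this assay only a limit, > 5000 nM. Compound 3 `O=C(O)c1ccc(COc2ccc(CNC(=O)[C@@H]3CCC(=O)N3Cc3ccc(Br)cc3)cc2)cc1` likewise gives in this assay only a limit, > 5000 nM. Among the measured compounds shown here, compound 1 therefore stands as the single resolved number in the set, which follows from the limit of > 5000 nM in this assay, at which 2 of the 3 values shown sit.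

The step of an at least 1.1-fold higher number from compound 1 to compound 2 (0.04 log units; that floor lies within the scatter) rests on the fact that compounds 1 and 2 differ only in the configuration as drawn and is bounded by a limit, so its size is known only as a floor. The step of an at least 1.1-fold higher number from compound 1 to compound 3 (0.04 log units; that floor lies within the scatter) is bounded in the same way.

Compound 4 `O=C(NCc1ccc(OCc2cn(-c3ccccc3)nn2)cc1)[C@@H]1CCC(=O)N1Cc1ccccc1` carries the change (1-phenyl-1H-1,2,3-triazol-4-yl in place of 4-carboxyphenyl on a saturated chain carbon bound to an oxygen on an aromatic ring). Neither measured step touches this position: the step from compound 1 to compound 2 concerns configuration, the step from compound 1 to compound 3 the benzyl on the lactam nitrogen, and both report only floors within the scatter. For the measured compounds named here, there is thus no measured step from which a direction for compound 4 in this assay can be read, and the expectation is a step of a 1.1-fold higher number from compound 1 to compound 4 (0.05 log units; within the scatter) with wide uncertainty. Compound 4 is estimated at 5000 nM, within 1500 nM to 16000 nM.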

Compound 4, half-maximal inhibitory concentration: > 5000 nM
Compound 4: only a limit was reported (the forecaster's own chance of this, stated with the estimate: 55%); the middle value sits exactly at the limit.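

In this assay compound 4 gives only a limit, > 5000 nM, not a number. Among the compounds shown here, this is the first reading at this position, and it comes to an at least 1.1-fold higher number from compound 1 to compound 4 (0.04 log units; that floor lies within the scatter), a floor whose true size stays unknown, so the exchange of 4-carboxyphenyl for 1-phenyl-1H-1,2,3-triazol-4-yl on the saturated chain carbon bound to an oxygen on an aromatic ring brings no value that resolves below the limit. The change removes the only hydrogen-bond donor of the leaving group and its carboxylic acid, yet the series still holds a single resolved number, so this position adds a third floor and no measured size: the limit of > 5000 nM in this assay, at which 3 of the 4 values shown sit.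

The compounds shown leave open whether the carboxylic acid, the benzene ring that carries it, or neither matters at this position, and how far compound 4 really lies from compound 1 in this assay. A plain benzyl in place of 4-carboxybenzyl, or a carboxylic acid on the phenyl of the 1-phenyl-1H-1,2,3-triazol-4-yl group, would separate the acid from the exchange of rings, provided the reading resolves below the limit.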